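From cyclopropylmethyl to isopropyl on the amide nitrogen

The compounds below may be only part of what the source reports. "The series", "measured", "known", "first", "only" and "open" are said of these compounds alone.

Of the compounds shown here, two have so far been measured in a functional assay on the whole organism with Rattus norvegicus as the target, at a dose of 20 mg/kg by the oral route; on this read-out lower numbers stand for less inhibition and higher numbers for more inhibition at the one dose given (going by the name of the read-out). Compound 1 `Cc1cccc2c1CC/C2=C\C(=O)NC1CC1` gives 7% in this assay. Compound 2 `O=C(/C=C1\CCc2ccc(F)cc21)NCC1CC1` gives 21% in this assay, which is the higher of the two numbers, and its gap to compound 1 lies beyond the usual scatter of repeated measurements. Compound 3 `CC(C)NC(=O)/C=C1\CCc2ccc(F)cc21` has not yet been measured in this assay. It differs from compound 2 at a single place: isopropyl in place of cyclopropylmethyl on an amide-type nitrogen. Among the measured compounds shown here, no pair of measured compounds shares this change, so nothing measured yet tells how this assay answers to it; the only anchor is the number of compound 2 itself. Compound 3 is therefore expected to stay near compound 2, with the step from compound 2 to compound 3 estimated at a number 3 percentage points lower from compound 2 to compound 3 (within the scatter), a change that is expected to fall within the scatter rather than beyond it. For compound 3 the estimated value in this assay is 18%, with an expected range from 4% to 34%.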

Compound 3, a percentage reported as inhibition, in the whole organism at one dose (the size of the read-out at that dose, not a potency): 71%
Compound 3: the middle estimate sits 53 percentage points below what was measured; measured number above the stated range.
By their numbers in this assay, from the lowest: compound 1; then compound 2; then compound 3.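

In this assay, isopropyl in place of cyclopropylmethyl on the amide-type nitrogen gives a number 50 percentage points higher from compound 2 to compound 3 (beyond the scatter) with the rest of the molecule unchanged. Among the compounds shown here, this is the first reading of a change at this position, and it shows that the read-out at the one oral dose given depends strongly on the group held there: the change is small on paper, with 3 heavy atoms entering for 4, the three-membered ring gone and the counts of hydrogen-bond donors and acceptors in the two groups the same. Nothing available on these compounds accounts for the size of the step.

For the compounds shown here, with only this pair differing at this nitrogen, it remains open whether the step belongs to the loss of the ring or to isopropyl itself, and whether ethyl, tert-butyl or cyclobutyl there would read nearer compound 2 or compound 3. As far as these compounds go, it is equally open whether the same change would carry over to the core of compound 1, and how far a reading at one dose reflects potency rather than the size of the effect at that dose.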